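The source may hold more compounds than are shown below. What is called first, only, known or untested is meant among the compounds shown, and "the series" means these compounds.

Working notes on the series. The compounds share one core, carried here by compound 1 `CCCSc1nnc(COc2ccc(Cl)cc2Cl)o1`, compound 2 `O=C(CCl)Sc1nnc(COc2ccc(Cl)cc2Cl)o1`, compound 3 `ClCCCSc1nnc(Cc2ccc(Cl)cc2Cl)o1` and the as yet unmeasured compound 4 `CCCSc1nnc(Cc2ccc(Cl)cc2Cl)o1`. In a functional assay on HepG2 cells (Homo sapiens) for cytotoxicity, with a stated time of 5 days (on this read-out higher numbers stand for lower toxicity in this test and lower numbers for higher toxicity in this test), compound 1 gives 19300 nM. For compound 2 the entry in this assay reads "not determined" (no result reported), so no result is available for it. For compound 3 the figure in this assay is a limit, > 50000 nM, and not a number; it is the one entry sitting at the limit of > 50000 nM in this assay, at which 1 of the 3 values shown sits. Going by the values given here, compound 1 and compound 3 differ from each other in more than one place, and no step between any two measured compounds is computed, so the evidence on single changes is empty.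

The step from compound 3 to compound 4 is hydrogen in place of chloro on a saturated chain carbon, three bonds along the chain from a sulfur. Without a computed step to lean on, the change is expected to move this assay little, if at all beyond the scatter, and the expected step from compound 3 to compound 4 is written as an at least 1.2-fold lower number from compound 3 to compound 4 (0.09 log units; that floor lies within the scatter). For compound 4 the estimate in this assay is 40000 nM, with a range from 15000 nM to 100000 nM, and a fair chance that only a limit is reported again.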

Compound 4, half-maximal cytotoxic concentration: > 50000 nM
Compound 4 was reported as a limit; the forecaster's own chance of this, stated with the estimate: 55%; at least 1.2-fold (0.09 log units) between middle value and limit.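

Compound 3 and compound 4 both stand only as limits in this assay, so no step between them can be read, and the two share the same limit: the limit of > 50000 nM in this assay, at which 2 of the 4 values shown sit.

The compounds shown leave open whether replacing 3-chloropropyl with propyl changes the half-maximal cytotoxic concentration at all.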